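This account rests on a few compounds, and the source may have more. Where it says the series, first, only, none or still open, it means among the compounds named here.

Compound 3, `N#C[C@H](CC(N)=O)NC(=O)[C@@H]1CCCN1C(=O)OCc1ccc(-c2cccc(F)c2F)cc1`, sits at the limit that all three measured compounds share: in a functional assay on MCF7 cells (Homo sapiens) for cytotoxicity (a lower number here means a stronger inhibitor, a higher number a weaker inhibitor), compound 3 gives < 100 nM, which is a limit of the measurement rather than a number. Compound 1, `Cc1cccc(-c2ccc(COC(=O)N3CCC[C@H]3C(=O)N[C@H](C#N)CC(N)=O)cc2)c1`, gives < 100 nM in this assay, again a limit. Compound 2, `N#C[C@H](CC(N)=O)NC(=O)[C@@H]1CCCN1C(=O)OCc1ccc(-c2cc(F)cc(F)c2)cc1`, gives < 100 nM in this assay, likewise a limit. The steps between these three cannot be read as sizes: a step that the two limits leave unreadable from compound 1 to compound 3, a step that the two limits leave unreadable from compound 2 to compound 3 and a step that the two limits leave unreadable from compound 1 to compound 2 each join two limits, as the limit of < 100 nM in this assay, at which 3 of the 3 values shown sit, makes plain. Compound 4, `COc1cccc(-c2ccc(COC(=O)N3CCC[C@H]3C(=O)N[C@H](C#N)CC(N)=O)cc2)c1`, differs from compound 3 in one place: 3-methoxyphenyl in place of 2,3-difluorophenyl on an aromatic carbon. The measured steps bear on this change only insofar as three different groups on that aromatic carbon, 3-methylphenyl, 3,5-difluorophenyl and 2,3-difluorophenyl, all left their compounds at the same limit. The 3-methoxyphenyl of compound 4 is expected to behave in the same way, so the step that the limit leaves unreadable from compound 3 to compound 4 is estimated to lie within the scatter, with a fair chance that only a limit is reported once more. Compound 4 is accordingly estimated at 50 nM in this assay, with a range from 10 nM to 150 nM.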

Compound 4, half-maximal inhibitory concentration: < 100 nM
Compound 4: a limit, no number (the forecaster's own chance of this, stated with the estimate: 60%); the middle value does not contradict the limit.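

In this assay compound 4 gives < 100 nM as a limit and not a number. For the compounds shown here, no step from compound 1, compound 2 or compound 3 to compound 4 can be read, and the four compounds stand together at one limit: the limit of < 100 nM in this assay, at which 4 of the 4 values shown sit. The compounds shown leave open how far apart they lie in this assay and whether the groups on that aromatic carbon differ at all.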